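One Aryl Group Swapped on a Shared Imidazole-Type Core

The source may hold more compounds than are shown below. What is called first, only, known or untested is meant among the compounds shown, and "the series" means these compounds.

Of the compounds shown here, three share a core and have been tested in a functional assay on A549 cells (Homo sapiens) for cytotoxicity, read by colorimetric assay and MTT assay, with a stated time of 3 days, tested at 1 uM; on this read-out higher numbers stand for a weaker effect at the one concentration tested and lower numbers for a stronger effect. Compound 1 `COc1ccc(-c2nc(-c3ccccc3)c(-c3ccc4c(c3)NC(=O)CO4)[nH]2)cc1` gives 101%, the highest of the three numbers shown. Compound 2 `Cc1ccccc1-n1cc(-c2ccccc2)c(-c2ccc3c(c2)NC(=O)CO3)n1` gives 94.8%, which sits within the usual scatter of the number for compound 1. Compound 3 `O=C1COc2ccc(-c3nn(-c4ccc(Cl)cc4)cc3-c3ccccc3)cc2N1` gives 84.4%, which lies beyond that scatter below compound 1. For the measured compounds named here, the only single-point change among measured pairs is the one from compound 2 to compound 3, with a number 10.4 percentage points lower from compound 2 to compound 3 (beyond the scatter); that change sits on an aromatic nitrogen and swaps one phenyl-type group for another.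

Compound 4 `O=C1COc2ccc(-c3[nH]c(-c4c[nH]c5ncccc45)nc3-c3ccccc3)cc2N1` has not yet been measured. Compared with compound 1 it carries a group of 9 heavy atoms (7 carbon, 2 nitrogen; one five-membered aromatic ring with 1 hetero atom, one six-membered aromatic ring with 1 hetero atom) in place of a group of 8 heavy atoms (7 carbon, 1 oxygen; one six-membered aromatic ring of carbon only), on an aromatic carbon. Going by the values given here, no measured pair changes the group on this aromatic carbon, so the step from compound 2 to compound 3 does not speak directly to it, and the three values together leave little room for a large movement in this assay. Compound 4 is therefore expected to stay close to compound 1, with a step of a number 6 percentage points lower from compound 1 to compound 4 (within the scatter), and the estimated value for compound 4 is 95%, within a range from 80% to 106%.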

Compound 4, a percentage reported as activity, at one concentration (the size of the read-out at that concentration, not a potency): 100%
The estimate for compound 4 lay 5 percentage points below the measured number, within the range that was stated.
By their numbers in this assay, from the lowest: compound 3; then compounds 2, 4 and 1 (each within the scatter of the next).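

In this assay, for the compounds shown here, the exchange on the aromatic carbon between two ring nitrogen atoms gives a number 1 percentage points lower from compound 1 to compound 4 (within the scatter), the first reading at this position, which the earlier step on an aromatic nitrogen could not provide. The exchange is not a small one: 4-methoxyphenyl, a single six-membered ring of carbon with no hydrogen-bond donor, leaves, and a group of a five-membered and a six-membered aromatic ring, each with a hetero atom and together carrying a hydrogen-bond donor, enters, yet the two compounds cannot be told apart at the one concentration tested. So, for this pair, neither the larger two-ring group nor the added donor separates compound 4 from compound 1 on this read-out, and no accompanying data offer an explanation for that.

Going by these compounds, whether a quite different group on this same carbon, such as a carboxylic acid, an aminomethyl group or a short alkyl chain, would move the number beyond the scatter remains open. On these data alone, a reading at a single concentration is also no potency, so how compound 1 and compound 4 would compare across a range of concentrations stays unknown.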